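Phenethylsulfanyl in place of methylamino on the diphosphate

The compounds below may be only part of what the source reports. "The series", "measured", "known", "first", "only" and "open" are said of these compounds alone.

Compound 2 `CNc1nc(=O)ccn1[C@@H]1O[C@H](COP(=O)(O)OP(=O)(O)O)[C@@H](O)[C@H]1O` is known in an in vitro functional assay on 1321-N1 cells for agonist activity at P2Y purinoceptor 4 (Homo sapiens), read by scintillation proximity assay and inositol phosphate accumulation (a higher number here means that more compound is needed for the effect, a lower number that less compound is needed), only by a limit: compound 2 gives >= 100000 nM, which is a limit and not a number, so it stands at the limit of >= 100000 nM in this assay, at which 1 of the 2 values shown sits. Compound 1 `O=c1ccn([C@@H]2O[C@H](COP(=O)(O)O)[C@@H](O)[C@H]2O)c(SCCc2ccccc2)n1` in this assay gives > 100000 nM, likewise a limit, at the limit of > 100000 nM in this assay, at which 1 of the 2 values shown sits. Compound 3 `O=c1ccn([C@@H]2O[C@H](COP(=O)(O)OP(=O)(O)O)[C@@H](O)[C@H]2O)c(SCCc2ccccc2)n1` differs from compound 2 by phenethylsulfanyl in place of methylamino on an aromatic carbon. Among the measured compounds shown here, no measured step shows this change, so its size in this assay is open; a modest gain is expected. Compound 3 is estimated at 40000 nM (range 4000 nM to 200000 nM), a step of an at least 2.5-fold lower number from compound 2 to compound 3 (0.39 log units; beyond the scatter).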

Compound 3, half-maximal effective concentration: >= 100000 nM
Compound 3: only a limit was reported; the forecaster's own chance of this, stated with the estimate: 55%; middle value at least 2.5-fold (0.39 log units) away from the limit.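

In this assay compound 3 gives >= 100000 nM, which is a limit. The steps to compound 3 from compound 1 and compound 2 cannot be read. The compounds shown leave open whether either change shifts the half-maximal effective concentration at all.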